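Swapping one five-membered ring at the assay limit

A few compounds are considered here, and "the series" means these few. Any claim that something is new, unique, unknown or untested is made for them only; others in the source may bear on it.

Compound 1 `Cn1nc2c(=O)n(CC3(O)CCN(Cc4ccc(-c5cnco5)cc4Cl)CC3)cnc2c1-c1ccc(CN)cc1`: >= 2.33 h (a limit)
Compound 2 `Cn1nc2c(=O)n(CC3(O)CCN(Cc4ccc(C5=CCCC5)cc4Cl)CC3)cnc2c1-c1ccc(CN)cc1`: >= 2.33 h (a limit)

In an ADME assay on microsomes from liver (Homo sapiens) for metabolic stability (on this read-out higher numbers stand for a longer-lived compound and lower numbers for a shorter-lived compound), compound 2 reads >= 2.33 h (a limit of the assay and not a number). Compound 1 also has only a limit, so neither compound has a measured half-life. Together they make up the limit of >= 2.33 h in this assay, at which 2 of the 2 values shown sit, and that is all the numbers show so far.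

Compound 3 `Cn1nc2c(=O)n(CC3(O)CCN(Cc4ccc(-c5ccco5)cc4Cl)CC3)cnc2c1-c1ccc(CN)cc1` differs from compound 2 in one place: furan-2-yl in place of cyclopent-1-en-1-yl on an aromatic carbon. A single measured step bears on this change, namely a step that the two limits leave unreadable from compound 1 to compound 2 (cyclopent-1-en-1-yl in place of 1,3-oxazol-5-yl on an aromatic carbon). Going by the values given here, its size cannot be read, so it offers no size to carry over, only two compounds that share the same limit. No step beyond the usual scatter is therefore expected in this assay and no direction is expected either, although this is thin ground for a forecast. The expected step is a step that the limit leaves unreadable from compound 2 to compound 3 on this reasoning. Compound 3 is estimated at 2.4 h with an expected range of 1.2 h to 4.5 h. A limit rather than a number is a likely outcome for compound 3 as well.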

Compound 3, half-life: >= 2.33 h
Compound 3: no number, only a limit (the forecaster's own chance of this, stated with the estimate: 65%); the middle value does not contradict the limit.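

Going by these compounds alone, compound 3, like compound 1 and compound 2, gives only a limit in this assay and no step among the three can be read: the limit of >= 2.33 h in this assay, at which 3 of the 3 values shown sit. The compounds shown leave open whether their half-lives differ at all, and how the 1,3-oxazol-5-yl, cyclopent-1-en-1-yl and furan-2-yl compounds would compare on measured numbers.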